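The compounds below may be only part of what the source reports. "The series", "measured", "known", "first", "only" and "open" are said of these compounds alone.

The measured compounds:
compound 1 `CCOc1ccc2nc(Cl)c(/C=N/NC(=O)c3cc4ccc(O)cc4oc3=O)cc2c1`, 17100 nM;
compound 2 `CCOc1ccc(NC(=O)c2cc3cc(Br)ccc3oc2=O)cc1`, 21800 nM;
compound 3 `Cc1noc(NS(=O)(=O)c2ccc(NC(=O)c3cc4cc([N+](=O)[O-])ccc4oc3=O)cc2)c1C`, 14300 nM.

All three were tested in a functional assay on CCRF-CEM cells (Homo sapiens) for antiproliferative activity, read by fluorescence and resazurin assay, with a stated time of 48 h; on this read-out lower numbers stand for stronger inhibition and higher numbers for weaker inhibition. On these numbers compound 1 sits between compound 2 and compound 3, and the three values lie within the usual scatter of one another, so none stands apart. Compound 4 `CCOc1ccc2nc(Cl)c(/C=N/NC(=O)c3cc4ccccc4oc3=O)cc2c1` differs from compound 1 in one place: hydrogen in place of hydroxy on an aromatic carbon. Among the compounds with values here, no pair of measured compounds shows this change alone, so there is no step to lean on. Compounds 2 and 3 lack a hydroxy on that part of the core and give numbers close to compound 1, which hints that the hydroxy matters little here. Compound 4 is therefore expected to move by a 1.2-fold higher number from compound 1 to compound 4 (0.07 log units; within the scatter), no further than the scatter. The estimate for compound 4 in this assay is 20000 nM, within 7000 nM to 60000 nM.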

Compound 4, half-maximal inhibitory concentration: 6320 nM
Compound 4: the middle estimate sits 3.2-fold (0.50 log units) above what was measured; measured number below the stated range.
By their numbers in this assay, from the lowest: compound 4; then compounds 3, 1 and 2 (each within the scatter of the next).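

In this assay the position turns out to be sensitive: hydrogen in place of hydroxy on this aromatic carbon gives a 2.7-fold lower number from compound 1 to compound 4 (0.43 log units; beyond the scatter) and so stronger inhibition. Within the data shown here, the hydroxy is therefore not needed for activity in this pair, and the earlier compounds could not show this, as none of them differed by this change alone. Nothing available explains why the number falls. Among the compounds shown, this position carries only hydroxy or hydrogen, so the effect of a methoxy, an amine or a fluorine there remains open.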